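The compounds below may be only part of what the source reports. "The series", "measured", "known", "first", "only" and "open" are said of these compounds alone.

Of the compounds shown here, three have so far been measured in a functional assay on the whole organism (plasma, strain Sprague-Dawley) with Rattus norvegicus as the target, with a stated time of 2 h, at a dose of 100 mg/kg by the oral route; a higher number here means a stronger effect of the compound at the dose given, a lower number a weaker effect. Compound 1 `c1ccc(C(/N=C2\CCCCCN2)C2CC2)cc1` gives 51% in this assay. Compound 3 `c1csc(C(/N=C2\CCCCCN2)C2CC2)c1` carries one change against compound 1, namely (thiophen-2-yl in place of phenyl on a saturated chain carbon bound to a double-bonded nitrogen and a saturated ring carbon), and in this assay compound 3 gives 44%. That change made a step of a number 7 percentage points lower from compound 1 to compound 3 (within the scatter). Compound 2 `c1ccc(C(/N=C2\CCCCCCN2)C2CC2)cc1` gives 58% in this assay; how the core of compound 2 differs from the core of compound 1 is not broken down here. The numbers of compound 2 and compound 1 lie within the scatter of each other, so no order between them can be read, whereas compound 3 lies beyond the scatter from compound 2.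

Compound 4 `c1csc(C(/N=C2\CCCCCCN2)C2CC2)c1` has not yet been measured. It stands to compound 2 exactly as compound 3 stands to compound 1: the change is thiophen-2-yl in place of phenyl on a saturated chain carbon bound to a double-bonded nitrogen and a saturated ring carbon. The place of the change is the same in both pairs, so this is the same change made on the core of compound 2 rather than on the core of compound 1. The step from compound 2 to compound 4 in this assay is therefore expected to be a number 7 percentage points lower from compound 2 to compound 4 (within the scatter), resting on the earlier step of a number 7 percentage points lower from compound 1 to compound 3 (within the scatter), which stayed within the scatter. Compound 4 is thus estimated to give 51% in this assay, with a likely range from 38% to 64%.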

Compound 4, a percentage reported as inhibition, in the whole organism at one dose (the size of the read-out at that dose, not a potency): 50%
Estimate against measurement, compound 4: 1 percentage points above; measured number inside the range.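

Putting thiophen-2-yl in place of phenyl on a second core gives, in this assay, a number 8 percentage points lower from compound 2 to compound 4 (within the scatter), and this step agrees with the one made on the first core: the same change on two cores in this assay, a number 7 percentage points lower (within the scatter) from compound 1 to compound 3 and a number 8 percentage points lower (within the scatter) from compound 2 to compound 4, 1 percentage points apart, within the scatter of two such steps

Within these two pairs, then, the change carries from one core to the other with a step of much the same size, so the step seen on one core was a fair guide to the step on the other. This does not show that the swap itself alters the effect, since each step on its own lies within the scatter and neither pair of compounds can be put in order; two pairs in this assay, read at a single dose, are also too few to make this a rule for the whole series.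

As far as these compounds go, it stays open whether a group of another kind in this place, such as a carboxylic acid or an amine in place of phenyl, would give a step beyond the scatter. From the compounds shown here alone, it also stays open whether the agreement between the two steps would hold on cores other than those of compound 1 and compound 2.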